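The compounds below may be only part of what the source reports. "The series", "measured", "known", "first", "only" and "open" are said of these compounds alone.

Measured in a functional assay on SK-N-SH cells (Homo sapiens) for cytotoxicity, read by MTT assay, with a stated time of 24 h; on this read-out higher numbers stand for weaker inhibition and lower numbers for stronger inhibition:
- Compound 1 `C/C(=N\NC(=O)/C(C#N)=C/c1ccc(O)cc1)c1c(O)c2ccc(O)cc2oc1=O`: 8120 nM
- Compound 2 `COc1ccc(/C=C(\C#N)C(=O)N/N=C(\C)c2c(O)c3ccc(O)cc3oc2=O)cc1OC`: 21500 nM
- Compound 3 `COc1cc(/C=C(\C#N)C(=O)N/N=C(\C)c2c(O)c3ccc(O)cc3oc2=O)cc(OC)c1OC`: 14600 nM

Compound 2 stands at the upper end of these numbers, within the scatter of compound 3 and clearly separated from compound 1. Compound 4 `C/C(=N\NC(=O)/C(C#N)=C/c1cccc([N+](=O)[O-])c1)c1c(O)c2ccc(O)cc2oc1=O` has not yet been measured. It has 3-nitrophenyl in place of 3,4-dimethoxyphenyl on a double-bonded chain carbon bound to a double-bonded chain carbon.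

Two measured steps change this same ring. The swap of 4-hydroxyphenyl for 3,4-dimethoxyphenyl gave a 2.6-fold higher number from compound 1 to compound 2 (0.42 log units; beyond the scatter), a modest change. The added methoxy gave a 1.5-fold lower number from compound 2 to compound 3 (0.17 log units; within the scatter). Neither step introduces a nitro group, so the data offer no direct measure of this change. For the measured compounds named here, they show only that changes on this ring have moved the number modestly, and compound 1, at 8120 nM, shows that a ring without the methoxy groups can give a lower number. A small move towards a lower number is therefore expected, namely a 1.8-fold lower number from compound 2 to compound 4 (0.25 log units; within the scatter). For compound 4 the estimated value is 12000 nM, with an expected range of 5000 nM to 28000 nM.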

Compound 4, half-maximal inhibitory concentration: 28300 nM
The estimate for compound 4 lay 2.4-fold (0.37 log units) below the measured number; the whole stated range lies below it.
By their numbers in this assay, from the lowest: compounds 1, 3, 2 and 4 (each within the scatter of the next, the first and the last beyond it).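

In this assay, placing 3-nitrophenyl in place of 3,4-dimethoxyphenyl on a double-bonded chain carbon bound to a double-bonded chain carbon gives a 1.3-fold higher number from compound 2 to compound 4 (0.12 log units; within the scatter), so this position does not tell these two rings apart, even though one carries methoxy groups and the other a nitro group. Set against the 4-hydroxyphenyl ring, the 3-nitrophenyl ring gives a 3.5-fold higher number from compound 1 to compound 4 (0.54 log units; beyond the scatter), which shows that the lack of methoxy groups alone does not bring a lower number and that compound 2 and compound 4 both stand higher than compound 1. No measurement offered here accounts for these differences.

On these data alone, whether the lower number of compound 1 is tied to its hydroxy group remains open. Also open, as far as these compounds go, is what an unsubstituted phenyl ring, or a ring bearing an amine or a carboxylic acid, would give at this position.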